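Chloro for fluoro on the anilide ring of a benzyloxy benzamide

The compounds below may be only part of what the source reports. "The series", "measured", "known", "first", "only" and "open" are said of these compounds alone.

Measured so far:
compound 1, `O=C(Nc1cccc(Cl)c1)c1cc(C(F)(F)F)ccc1OCc1ccccc1`, 25.1 nM
compound 2, `O=C(Nc1cccc(F)c1)c1cc(C(F)(F)F)ccc1OCc1ccc(F)cc1`, 31.6 nM

Of the compounds shown here, two have been measured in an assay on Sf9 cells for inhibition of Leucine-rich repeat serine/threonine-protein kinase 2 (Homo sapiens), read by TR-FRET, with stated times of 30 min and 2 h; a higher number here means a weaker inhibitor, a lower number a stronger inhibitor. Compound 1 gives 25.1 nM, and compound 2 gives 31.6 nM. The two numbers sit within the usual scatter of each other, so neither compound can be called apart from the other; compound 2 simply carries the higher of the two figures.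

Compound 3, `O=C(Nc1cccc(Cl)c1)c1cc(C(F)(F)F)ccc1OCc1ccc(F)cc1`, has not been measured. It differs from compound 2 in one place: chloro in place of fluoro on an aromatic carbon, on an aromatic carbon of a six-membered aromatic ring of carbon only, meta to a large group. Within the data shown here, no step between measured compounds that shows this change on its own is available, and compound 1, which already bears the chloro group, reads close to compound 2. On that basis compound 3 is expected to land near both measured compounds, with a step of a 1.3-fold lower number from compound 2 to compound 3 (0.10 log units; within the scatter) that stays within the scatter. Compound 3 is estimated at 25 nM in this assay, with a range from 10 nM to 63 nM.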

Compound 3, half-maximal inhibitory concentration: 12.6 nM
For compound 3 the middle estimate is 2.0-fold (0.30 log units) above the measured one, within the range that was stated.
By their numbers in this assay, from the lowest: compounds 3, 1 and 2 (each within the scatter of the next, the first and the last beyond it).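

In this assay the swap of 3-fluorophenyl to 3-chlorophenyl can now be read on its own, with the rest of the molecule unchanged. The first two compounds could not offer this. They differ in two places. The swap gives a modest step beyond the scatter (a 2.5-fold lower number from compound 2 to compound 3 (0.40 log units; beyond the scatter)), while fluoro in place of hydrogen on the other ring gives a step that stays within the scatter (a 2.0-fold lower number from compound 1 to compound 3 (0.30 log units; within the scatter)), so that second change cannot be told from no change. Nothing at hand explains why chloro and fluoro differ at this place.

As far as these compounds go, whether bromo, methyl or a nitrile at the same place would extend, match or reverse this step remains open. So does whether the step would hold on a different core.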